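Compound 3 to compound 4: one group exchanged

The source may hold more compounds than are shown below. What is called first, only, known or untested is meant among the compounds shown, and "the series" means these compounds.

Compound 3 (`COc1cc(/C=C2\CN(S(=O)(=O)c3ccc(NC(C)=O)cc3)C/C(=C\c3ccc(C#N)cc3)C2=O)cc(OC)c1OC`) reads 1890 nM in a functional assay on QGY-7703 cells (Homo sapiens) for cytotoxicity, read by MTT assay, with a stated time of 24 h (on this read-out higher numbers stand for weaker inhibition and lower numbers for stronger inhibition), and sits within the scatter of compound 2 (`COc1cc(/C=C2\CN(S(=O)(=O)c3ccc(NC(C)=O)cc3)C/C(=C\c3cccc([N+](=O)[O-])c3)C2=O)cc(OC)c1OC`) at 2550 nM and of compound 1 (`COc1cc(/C=C2\CN(S(=O)(=O)c3ccc(NC(C)=O)cc3)C/C(=C\c3ccccc3F)C2=O)cc(OC)c1`) at 3690 nM on the same read-out. Moving to compound 4 (`COc1cc(/C=C2\CN(S(=O)(=O)c3ccc(NC(C)=O)cc3)C/C(=C\c3cc(OC)c(OC)c(OC)c3)C2=O)cc(OC)c1`) brings one structural change (3,5-dimethoxyphenyl in place of 4-cyanophenyl on a double-bonded chain carbon bound to a double-bonded ring carbon) on a double-bonded chain carbon bound to a double-bonded ring carbon. Within the data shown here, the only measured step at this place (a 1.3-fold lower number from compound 2 to compound 3 (0.13 log units; within the scatter)) stays within the scatter, and it involves no 3,5-dimethoxyphenyl group. The expected step in this assay (a 1.3-fold higher number from compound 3 to compound 4 (0.12 log units; within the scatter)) is therefore small, with no direction expected beyond the scatter. The estimate for compound 4 is an expected 2500 nM (estimated range 1100 nM to 5500 nM).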

Compound 4, half-maximal inhibitory concentration: 2020 nM
Beside the measured number, compound 4's estimate is 1.2-fold (0.09 log units) above it; low and high end bracket the measured number.
By their numbers in this assay, from the lowest: compounds 3, 4, 2 and 1 (each within the scatter of the next).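

In this assay, 3,5-dimethoxyphenyl in place of 4-cyanophenyl gives a 1.1-fold higher number from compound 3 to compound 4 (0.03 log units; within the scatter), and in place of 3-nitrophenyl it gives a 1.3-fold lower number from compound 2 to compound 4 (0.10 log units; within the scatter). With 3,4,5-trimethoxyphenyl in place of 2-fluorophenyl the result is a 1.8-fold lower number from compound 1 to compound 4 (0.26 log units; within the scatter), so methoxy-bearing, nitrile-bearing, nitro-bearing and fluorine-bearing phenyl groups at this place all stay within the scatter of one another across these four compounds. No supporting evidence accompanies these numbers.

On these data alone, whether an amine, a carboxylic acid or a longer alkyl chain at this place would move the number beyond the scatter remains open.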